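A few compounds are considered here, and "the series" means these few. Any claim that something is new, unique, unknown or untested is made for them only; others in the source may bear on it.

The measured compounds, all tested in a functional assay on HEK293 cells (Homo sapiens) for cytotoxicity; on this read-out higher numbers stand for lower toxicity in this test and lower numbers for higher toxicity in this test:
Compound 1, `COc1ccc([C@H]2CC(=O)N(c3cc(N)cc(N)c3)C2)cc1OC1CCCC1`: > 10000 nM
Compound 2, `COc1ccc([C@H]2CC(=O)N(c3ccc(C#N)cc3)C2)cc1OC1CCCC1`: > 10000 nM
Compound 3, `COc1ccc([C@H]2CC(=O)N(c3cccc([S+](C)[O-])c3)C2)cc1OC1CCCC1`: > 10000 nM

Each of these values is a limit of the assay rather than a number. In this assay compound 1 gives > 10000 nM, a limit. Compound 2 gives > 10000 nM, again a limit. Compound 3 gives > 10000 nM, also a limit. Compound 3 therefore stands at the same limit as the other two, and nothing separates the three, since (the limit of > 10000 nM in this assay, at which 3 of the 3 values shown sit). The steps between them cannot be sized: a step that the two limits leave unreadable from compound 1 to compound 2, a step that the two limits leave unreadable from compound 1 to compound 3 and a step that the two limits leave unreadable from compound 2 to compound 3.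

Compound 4, `COc1ccc([C@H]2CC(=O)N(c3cccc(NS(=O)(=O)c4c(F)cccc4F)c3)C2)cc1OC1CCCC1`, is not yet measured. It differs from compound 3 at one place: a group of 12 heavy atoms (6 carbon, 1 nitrogen, 2 oxygen, 2 fluorine, 1 sulfur; one six-membered aromatic ring of carbon only) in place of a group of 3 heavy atoms (1 carbon, 1 oxygen, 1 sulfur; no ring), on an aromatic carbon. The ((2,6-difluorophenyl)sulfonyl)amino group enters where a group of 3 heavy atoms without a ring left, on an aromatic carbon of a six-membered aromatic ring of carbon only, meta to a large group.

Among the compounds with values here, none of the measured steps has a readable size, so they cannot say how large the step to compound 4 will be. What they do show is that exchanging the group on the amide-type nitrogen in a ring among compounds 1, 2 and 3 never brought toxicity into the measured range. The expectation for compound 4 is accordingly a step that the limit leaves unreadable from compound 3 to compound 4 in this assay, none beyond the scatter, most likely another limit. Compound 4 is estimated at 15000 nM, within 5000 nM to 50000 nM.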

Compound 4, half-maximal cytotoxic concentration: > 10000 nM
Compound 4: no number, only a limit; the forecaster's own chance of this, stated with the estimate: 75%; the middle value lies beyond the limit too.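

In this assay compound 4 gives > 10000 nM, again a limit of the assay rather than a number. The step between compound 3 and compound 4 therefore cannot be read, and nothing separates the compounds shown: the limit of > 10000 nM in this assay, at which 4 of the 4 values shown sit. Left open is what true value each of the four compounds has, and whether the ((2,6-difluorophenyl)sulfonyl)amino group changes it at all.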